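The source may hold more compounds than are shown below. What is called first, only, known or untested is meant among the compounds shown, and "the series" means these compounds.

Compound 1 `N=c1oc2c(O)cccc2cc1C(=O)Nc1cccc(F)c1` — > 10000 nM
Compound 2 `N=c1oc2c(O)cccc2cc1C(=O)Nc1ccc(F)cc1` — > 10000 nM

In an assay on isolated protein for inhibition of aldo-keto reductase family 1 member C4 (Homo sapiens), using NADPH (a higher number here means a weaker inhibitor, a lower number a stronger inhibitor), compound 1 reaches only a limit, > 10000 nM. In this assay compound 2 likewise reaches only a limit, > 10000 nM. The step that the two limits leave unreadable from compound 1 to compound 2 cannot be read, because of the limit of > 10000 nM in this assay, at which 2 of the 2 values shown sit. Compound 2 thus stands at the limit of this assay and no closer. Compound 3 `N=c1oc2c(O)cccc2cc1C(=O)Nc1ccccc1Cl` differs from compound 2 by 2-chlorophenyl in place of 4-fluorophenyl on an amide-type nitrogen. No readable measured step bears on this change, so the expectation rests on compound 2 alone. Compound 3 is therefore expected to stay near the limit, with an estimated step that the limit leaves unreadable from compound 2 to compound 3, giving 15000 nM, between 4000 nM and 60000 nM.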

Compound 3, half-maximal inhibitory concentration: > 10000 nM
Compound 3 was reported as a limit (the forecaster's own chance of this, stated with the estimate: 75%); the middle value lies beyond the limit too.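

Among these compounds, no step among compound 1, compound 2 and compound 3 can be read in this assay, because all three stop at a limit: the limit of > 10000 nM in this assay, at which 3 of the 3 values shown sit. On these data alone, whether any other group on the amide-type nitrogen would give a readable value in this assay stays open.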